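Working notes: from compound 2 to compound 4

A few compounds are considered here, and "the series" means these few. Any claim that something is new, unique, unknown or untested is made for them only; others in the source may bear on it.

Measured in an in vitro functional assay on HEK ts201 cells for antagonist activity at Neuronal acetylcholine receptor; alpha3/beta4 (Homo sapiens), read by fluorescence and calcium flux; a higher number here means a weaker inhibitor, a lower number a stronger inhibitor:
compound 1 `O=C(OCC1CCCN(CCCn2cc(-c3ccccc3)nn2)C1)c1ccccc1-c1ccccc1`: 389000 nM
compound 2 `COc1ccc(CC2CC(=O)N(c3ccccc3C(=O)OCC3CCCN(CCCc4ccccc4)C3)C2=O)cc1`: 28800 nM
compound 3 `O=C(CCc1ccccc1)N1CCCC(CN(Cc2ccccc2-c2ccccc2)Cc2ccccc2-c2ccccc2)C1`: 40700 nM

Compound 2 has the lowest of the three numbers in this assay. Its nearest neighbour is compound 3, whose value lies within the usual scatter of compound 2, so the two cannot be ranked against each other. Compound 1 stands furthest away, with a number beyond the scatter and on the higher side, so compound 1 is the weaker inhibitor of that pair.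

Compound 4 `O=C(OCC1CCCN(CCCc2ccccc2)C1)c1ccccc1N1C(=O)CC(CCc2ccccc2)C1=O` is not yet measured. It differs from compound 2 in one place: benzyl in place of 4-methoxyphenyl on a saturated chain carbon bound to a saturated ring carbon. Among the measured compounds shown here, no pair of measured compounds differs in only this place, so the size of this step has no precedent here; the three measured values tell nothing about the methoxy group by itself, since compound 1 and compound 3 differ from compound 2 in several places at once.

Expectation: the change is small in counted atoms and removes one hydrogen-bond acceptor, and with nothing else altered the step of a 1.2-fold higher number from compound 2 to compound 4 (0.08 log units; within the scatter) is expected to stay within the scatter, with no clear direction. For compound 4 the estimate in this assay is 35000 nM, within a range of 12000 nM to 100000 nM.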

Compound 4, half-maximal inhibitory concentration: 33100 nM
Estimate against measurement, compound 4: 1.1-fold (0.02 log units) above, and the stated range covers the measured number.
By their numbers in this assay, from the lowest: compounds 2, 4 and 3 (each within the scatter of the next); then compound 1.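

In this assay, among the compounds shown here, the exchange of 4-methoxyphenyl for benzyl on a saturated chain carbon bound to a saturated ring carbon gives a 1.1-fold higher number from compound 2 to compound 4 (0.06 log units; within the scatter), the first step in this set that isolates a single place and so the first direct reading at this position. Within the scatter, the two groups cannot be told apart here, so the hydrogen-bond acceptor counted on 4-methoxyphenyl, absent from benzyl, has no readable effect on the number in this pair, and the same holds for the difference read one bond further out, 4-methoxybenzyl to phenethyl. No supporting measurement on either group accompanies this result, and the step stands as an observation without an explanation.

Open, going by these compounds, is whether a group of another kind at this place, such as an amine or a carboxylic acid, would move the number beyond the scatter of compound 2. For the compounds shown here, also open is whether a longer chain carrying the same aromatic ring would stay within the scatter, since this one step covers only a single exchange on a single core.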